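Cytotoxicity notes: compound 4 from the pyridin-3-yl analogue

A few compounds are considered here, and "the series" means these few. Any claim that something is new, unique, unknown or untested is made for them only; others in the source may bear on it.

Values in an ADME assay on THP-1 cells (Homo sapiens) for cytotoxicity, read by MTT assay, with a stated time of 72 h; a lower number here means that less compound is needed, a higher number that more compound is needed for the effect:
- compound 1 `Cc1cc(-c2ccc3[nH]c(=O)nc(-c4ccccc4)c3c2)ccn1`: > 50000 nM, a limit.
- compound 2 `O=c1nc(-c2ccccc2)c2cc(-c3cccnc3)ccc2[nH]1`: > 50000 nM, a limit.
- compound 3 `Cc1cncc(-c2ccc3[nH]c(=O)nc(-c4ccccc4)c3c2)c1`: > 50000 nM, a limit.

Compound 2 stands at a limit of this assay and has no number of its own. The two compounds that differ from it in one place stand at the same limit, so the steps a step that the two limits leave unreadable from compound 1 to compound 2 and a step that the two limits leave unreadable from compound 2 to compound 3 cannot be read, and neither can a step that the two limits leave unreadable from compound 1 to compound 3. Among the measured compounds shown here, the only evidence on the measured set is the limit of > 50000 nM in this assay, at which 3 of the 3 values shown sit.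

Compound 4 `CN(C)c1ccc(-c2ccc3[nH]c(=O)nc(-c4ccccc4)c3c2)cn1` is reached from compound 2 by dimethylamino in place of hydrogen on an aromatic carbon. For the measured compounds named here, no measured step in this assay bears readably on that change; every neighbour of compound 2 sits at the limit. The expectation is therefore that compound 4 also lands at the limit, with an estimated step that the limit leaves unreadable from compound 2 to compound 4 that carries no readable size. Compound 4 is estimated at 60000 nM, in a range from 25000 nM to 200000 nM, most likely reported only as a limit.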

Compound 4, half-maximal effective concentration: > 50000 nM
Compound 4 gave a limit, no number (the forecaster's own chance of this, stated with the estimate: 85%); the middle value lies beyond the limit too.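

With compound 2 and compound 4 both standing at a limit, the step between them cannot be read and the series gains no new step: the limit of > 50000 nM in this assay, at which 4 of the 4 values shown sit.

The compounds shown leave open whether any change to the shared core would give a number of its own in this assay.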